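Replacing the enone arm with a chlorobenzyl ether

A few compounds are considered here, and "the series" means these few. Any claim that something is new, unique, unknown or untested is made for them only; others in the source may bear on it.

Compound 1 `COC(=O)c1cc(-c2cccc(NC(=O)c3ccc(/C=C/C(=O)c4cccnc4)cc3)c2)on1`: "not determined" (no result reported) in an ADME assay on Vero cells (Chlorocebus sabaeus) for cytotoxicity, read by MTT assay, with a stated time of 72 h; a higher number here means that more compound is tolerated, a lower number that less compound is tolerated.
Compound 2 `CCOc1ccc(C(=O)/C=C/c2ccc(C(=O)Nc3cccc(-c4cc(C(=O)OC)no4)c3)cc2)cc1`: > 40 ug/mL.

Compound 1 has no number reported. For compound 2 the value > 40 ug/mL is a limit of the assay, not a number; this is the situation described by the limit of > 40 ug/mL in this assay, at which 1 of the 2 values shown sits. Compound 3 `COC(=O)c1cc(-c2cccc(NC(=O)c3ccc(OCc4ccc(Cl)cc4)cc3)c2)on1` differs from compound 1 by (4-chlorobenzyl)oxy in place of 2-((pyridin-3-yl)carbonyl)ethenyl on an aromatic carbon. Among the measured compounds shown here, with no measured step to draw on, the expectation for compound 3 in this assay is a shift no larger than the scatter, most likely again a limit. Compound 3 is estimated at 40 ug/mL, with a range from 20 ug/mL to 80 ug/mL.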

Compound 3, half-maximal cytotoxic concentration: > 80 ug/mL
Compound 3 ended at the assay's limit (the forecaster's own chance of this, stated with the estimate: 70%); middle value at least 2.0-fold (0.30 log units) from the limit.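

Compound 1 has no number shown in this assay, and compound 3 gives only a limit, > 80 ug/mL, so no step can be read between them. Going by these compounds, whether (4-chlorobenzyl)oxy in place of 2-((pyridin-3-yl)carbonyl)ethenyl changes tolerance at all remains open.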